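The compounds below may be only part of what the source reports. "The series", "measured", "known", "first", "only" and "open" are said of these compounds alone.

Measured compounds:
compound 1 `Cc1nn(-c2ncnc3nc[nH]c23)c2c1C(OC1CCCC1)CC(=O)N2` — 2 nM
compound 2 `Cc1nn(-c2ncnc3nc[nH]c23)c2c1C(C(=O)N(C)c1nccs1)CC(=O)N2` — 18 nM

In a functional assay on HEK293 cells for agonist activity at G-protein coupled receptor 39 (Homo sapiens), read by scintillation proximity assay and inositol phosphate accumulation, with a stated time of 75 min, in the presence of a further agent that is not named here (on this read-out higher numbers stand for an effect only at larger amounts of compound and lower numbers for an effect already at smaller amounts), compound 1 gives 2 nM. Among the measured compounds shown here, in the same read-out compound 2 gives 18 nM, the higher of the two numbers in hand; the only step within the pair is a 9.0-fold higher number from compound 1 to compound 2 (0.95 log units; beyond the scatter).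

Compound 3 `Cc1nn(-c2ncnc3nc[nH]c23)c2c1C(OC(=O)c1ccc(F)cc1)CC(=O)N2` is next in line. It differs from compound 2 in one place: ((4-fluorophenyl)carbonyl)oxy in place of methyl(1,3-thiazol-2-yl)carbamoyl on a saturated ring carbon. For the measured compounds named here, the one step that bears on this position is a 9.0-fold higher number from compound 1 to compound 2 (0.95 log units; beyond the scatter), which moved the number away from the oxygen-linked substituent of compound 1 toward the carbamoyl of compound 2. Compound 3 returns to an oxygen-linked substituent on the same saturated ring carbon, so a step back toward the lower number of compound 1 is expected rather than a move further up. The estimate for compound 3 is 6 nM (range 1.5 nM to 25 nM), which is an expected step of a 3.0-fold lower number from compound 2 to compound 3 (0.48 log units; beyond the scatter).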

Compound 3, half-maximal effective concentration: 4 nM
Estimate against measurement, compound 3: 1.5-fold (0.18 log units) above; the measured number falls inside the stated range.
By their numbers in this assay, from the lowest: compounds 1 and 3 (each within the scatter of the next); then compound 2.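

In this assay, ((4-fluorophenyl)carbonyl)oxy in place of methyl(1,3-thiazol-2-yl)carbamoyl on the saturated ring carbon gives a 4.5-fold lower number from compound 2 to compound 3 (0.65 log units; beyond the scatter), so among these compounds the two oxygen-linked substituents both stand beyond the scatter from the carbamoyl of compound 2. (4-Fluorophenyl)carbonyl in place of cyclopentyl on the same oxygen gives a 2.0-fold higher number from compound 1 to compound 3 (0.30 log units; within the scatter), so the number does not separate these two quite different groups on that oxygen. Nothing measured here gives a cause for either step.

Going by these compounds, whether the linking oxygen itself matters remains open, since every low number here carries it; a secondary amine or a plain butyl chain on the same saturated ring carbon would address that. On these data alone, how far the tolerance on the oxygen extends also remains open, for example to a simple acetyl group.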